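The compounds below may be only part of what the source reports. "The series", "measured", "known", "first", "only" and "open" are said of these compounds alone.

Measured so far:
Compound 1, `CC(C)COc1ccc2c(Cl)ccnc2c1`, gives 3190 nM in a functional assay on SK-OV-3 cells (Homo sapiens) for cytotoxicity, read by MTT assay, with a stated time of 48 h; a higher number here means a weaker inhibitor, a lower number a stronger inhibitor.
Compound 2, `CCOc1ccc2c(Cl)ccnc2c1`, gives 3460 nM in this assay.

Compound 2 sits at one end of these two numbers, but the single step that joins them, a 1.1-fold higher number from compound 1 to compound 2 (0.04 log units; within the scatter), lies within the scatter, so the two compounds cannot be told apart on the data shown. Both share the same core and differ only in the chain attached to the oxygen on the aromatic ring.

Compound 3, `Clc1ccnc2cc(OCCCc3ccccc3)ccc12`, has not yet been measured. It differs from compound 2 by benzyl in place of hydrogen on a saturated chain carbon, two bonds along the chain from an oxygen on an aromatic ring. Going by the values given here, the only measured step that bears on this change is the one between compound 1 and compound 2, which also alters the chain on that same oxygen, and it stayed within the scatter. The chain in compound 3 is longer and carries a ring, so the data give no firm direction; the step is therefore expected to be small, a 1.2-fold lower number from compound 2 to compound 3 (0.06 log units; within the scatter), with no change beyond the scatter as the most likely outcome. Compound 3 is accordingly estimated at 3000 nM, with a range from 900 nM to 10000 nM.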

Compound 3, half-maximal inhibitory concentration: 3610 nM
Beside the measured number, compound 3's estimate is 1.2-fold (0.08 log units) below it, within the range that was stated.
By their numbers in this assay, from the lowest: compounds 1, 2 and 3 (each within the scatter of the next).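

In this assay, the step from a hydrogen to benzyl on a saturated chain carbon, two bonds along the chain from an oxygen on an aromatic ring, is a 1.0-fold higher number from compound 2 to compound 3 (0.02 log units; within the scatter) and stays within the scatter. The earlier step only exchanged one small saturated chain for another on that oxygen, whereas this one brings in 7 heavy atoms and a six-membered aromatic ring of carbon only, and the number still does not move beyond the scatter, so this position accepts a far larger group without a readable change in this cell-killing measure. Nothing in the data shown explains why so large a change leaves the number where it was.

As far as these compounds go, it remains open whether a group of a different kind on that chain, such as an amine or a carboxylic acid, or a longer chain, would give the same result. From the compounds shown here alone, it is also open whether any change to the group on that oxygen can shift the number beyond the scatter, or whether that would take a change on the shared core itself.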